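This account rests on a few compounds, and the source may have more. Where it says the series, first, only, none or still open, it means among the compounds named here.

Of the compounds shown here, three of a shared core have been measured so far. Compound 1 `COc1ccc(C[C@@H](O)/C=C/C=C/C(=O)NCc2ccccc2)cc1OC` gives 33600 nM in a functional assay on MCF7 cells (Homo sapiens) for antiproliferative activity, read by sulforhodamine B assay, with a stated time of 48 h (on this read-out lower numbers stand for stronger inhibition and higher numbers for weaker inhibition), the highest of the three numbers. Compound 2 `COc1ccc(CNC(=O)/C=C/C=C/[C@H](O)Cc2ccc(OC)c(OC)c2)cc1` gives 26600 nM, and the change from hydrogen to methoxy on an aromatic carbon yields a 1.3-fold lower number from compound 1 to compound 2 (0.10 log units; within the scatter). Compound 3 `COc1ccc(C[C@@H](O)/C=C/C=C/C(=O)N2CCN(c3ccccn3)CC2)cc1OC`, in which the amide carries a different ring, gives 23600 nM; set beside compound 1, the two values lie close together.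

The next compound is compound 4 `CCN1CCN(C(=O)/C=C/C=C/[C@H](O)Cc2ccc(OC)c(OC)c2)CC1`. It differs from compound 1 in this way: 4-ethylpiperazin-1-yl in place of benzylamino on a carbonyl carbon. Among the measured compounds shown here, no measured step exchanges the benzylamino group, so the only guide is what compound 1 and compound 3 show at the amide, and those two numbers sit near each other. On that basis no step beyond the scatter is expected, in either direction. Compound 4 is therefore expected to give about 27000 nM, with a range from 10000 nM to 70000 nM. The step implied by this expectation is a 1.2-fold lower number from compound 1 to compound 4 (0.09 log units; within the scatter).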

Compound 4, half-maximal inhibitory concentration: 11500 nM
The estimate for compound 4 lay 2.3-fold (0.37 log units) above the measured number, and the stated range covers the measured number.
By their numbers in this assay, from the lowest: compound 4; then compounds 3, 2 and 1 (each within the scatter of the next).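

In this assay the substituent on the carbonyl carbon now gives a step beyond the scatter: 4-ethylpiperazin-1-yl in place of benzylamino yields a 2.9-fold lower number from compound 1 to compound 4 (0.47 log units; beyond the scatter), a modest change. The second step shows that the group on the ring's amine nitrogen also counts, since ethyl in place of pyridin-2-yl yields a 2.1-fold lower number from compound 3 to compound 4 (0.31 log units; beyond the scatter), again modest, with the ring itself unchanged. Nothing available accounts for either step.

The compounds shown leave open whether a methyl or a longer chain on that ring nitrogen would move the number further, or whether ethyl is already the better group. They also leave open whether a hydroxyl or an amine at the end of such a chain would change the number at all.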